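A 1,3-thiazol-2-yl group on the amino nitrogen of compound 2

The compounds below may be only part of what the source reports. "The series", "measured", "known", "first", "only" and "open" are said of these compounds alone.

Compound 1 `N#Cc1c(Cl)nc(SCc2nc3ccccc3[nH]2)nc1-c1ccccc1`: 4.46 nM
Compound 2 `CNc1nc(SCc2nc3ccccc3[nH]2)nc(-c2ccccc2)c1C#N`: 19.2 nM

Among the compounds with values here, in a functional assay on U-937 cells (Homo sapiens) for cytotoxicity, read by MTT assay, with a stated time of 3 days (on this read-out higher numbers stand for weaker inhibition and lower numbers for stronger inhibition), compound 2 gives 19.2 nM, the higher of the two numbers measured so far. Compound 3 `N#Cc1c(Nc2nccs2)nc(SCc2nc3ccccc3[nH]2)nc1-c1ccccc1` carries 1,3-thiazol-2-yl in place of methyl on a nitrogen on an aromatic ring. Within the data shown here, only one measured step bears on this change, and only indirectly: a 4.3-fold higher number from compound 1 to compound 2 (0.63 log units; beyond the scatter), which put methylamino in place of chloro on an aromatic carbon. That step is modest but beyond the scatter. Among the measured compounds shown here, no measured compound shows a change on the nitrogen itself, so the data give no firm direction. A step of modest size or smaller is therefore expected in this assay, possibly none beyond the scatter. The estimated step is a 1.3-fold lower number from compound 2 to compound 3 (0.11 log units; within the scatter). For compound 3 the estimated value is 15 nM, with an expected range from 4 nM to 60 nM.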

Compound 3, half-maximal inhibitory concentration: 3.8 nM
Beside the measured number, compound 3's estimate is 3.9-fold (0.60 log units) above it; the whole stated range lies above it.
By their numbers in this assay, from the lowest: compounds 3 and 1 (each within the scatter of the next); then compound 2.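

In this assay, the substituent on the nitrogen turns out to matter: 1,3-thiazol-2-yl in place of methyl gives a 5.1-fold lower number from compound 2 to compound 3 (0.70 log units; beyond the scatter), which runs opposite in direction to the earlier step, a 4.3-fold higher number from compound 1 to compound 2 (0.63 log units; beyond the scatter). An amino nitrogen on that aromatic carbon therefore need not go with a higher number, since (1,3-thiazol-2-yl)amino in place of chloro gives a 1.2-fold lower number from compound 1 to compound 3 (0.07 log units; within the scatter). No measurement is available that would explain this reversal.

As far as these compounds go, how a phenyl, a pyridin-2-yl or an ethyl group on that nitrogen would compare remains open, and so does whether the sulfur of the 1,3-thiazol-2-yl group plays any part. Also open, from the compounds shown here alone, is how an unsubstituted amino group or a morpholine in place of chloro on the aromatic carbon would read.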